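The compounds below may be only part of what the source reports. "The series", "measured", "known", "first", "only" and "open" are said of these compounds alone.

Compound 2 `Cc1ccc(Nc2nc(N)nc(COc3ccc(Cl)c(N4CCCC4=O)c3)n2)cc1Cl` gives 2450 nM in an assay on COS-7 cells for agonist activity at Free fatty acid receptor 1 (Homo sapiens), read by scintillation counting and inositol phosphate accumulation, with a stated time of 90 min (a higher number here means that more compound is needed for the effect, a lower number that less compound is needed), the highest of the two numbers in hand, while compound 1 `Cc1ccc(Nc2nc(N)nc(COc3cccc(N4CCCC4=O)c3)n2)cc1Cl` gives 820 nM. Going by the values given here, the only measured step, a 3.0-fold higher number from compound 1 to compound 2 (0.48 log units; beyond the scatter), shows that placing chloro where hydrogen had been pushed the number up. Compound 3 `COc1ccc(OCc2nc(N)nc(Nc3ccc(C)c(Cl)c3)n2)cc1N1CCCC1=O` differs from compound 2 by methoxy in place of chloro on an aromatic carbon. Among the compounds with values here, no measured step covers a methoxy in that spot, so the direction is uncertain, and the step from compound 2 is expected to be a 1.5-fold lower number from compound 2 to compound 3 (0.19 log units; within the scatter), a small change. Compound 3 is therefore estimated at 1600 nM, within a range from 600 nM to 4500 nM.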

Compound 3, half-maximal effective concentration: 20200 nM
Compound 3: the middle estimate sits 13-fold (1.10 log units) below what was measured; the whole stated range lies below it.
By their numbers in this assay, from the lowest: compound 1; then compound 2; then compound 3.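

In this assay swapping chloro for methoxy on this aromatic carbon, ortho to a 2-oxopyrrolidin-1-yl group, gives an 8.2-fold higher number from compound 2 to compound 3 (0.92 log units; beyond the scatter) and replacing hydrogen with methoxy gives a 25-fold higher number from compound 1 to compound 3 (1.39 log units; beyond the scatter) so the cost of substitution here can be far larger than chloro alone showed. The order is hydrogen lowest, then chloro, then methoxy, so the number depends strongly on which group sits here. Nothing in hand explains this order. On these data alone, whether fluoro, an amine or a carboxylic acid on this carbon would give a lower number than hydrogen stays open.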